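This account rests on a few compounds, and the source may have more. Where it says the series, first, only, none or still open, it means among the compounds named here.

Measured in an in vitro ADME assay on microsomes from liver (Homo sapiens) for pharmacokinetics, read by LC-MS; on this read-out lower numbers stand for slow clearance and higher numbers for fast clearance:
- compound 1 `Cc1ccc2c(c1)nc(C)n2-c1ccc(C(=O)NC2CC2)s1`: 8 mL/min/kg
- compound 2 `Cc1nc2ccc(OC(F)(F)F)cc2n1-c1ccc(C(=O)NC2CC2)s1`: 10 mL/min/kg

Compound 1 stands within the scatter of compound 2, so the two numbers cannot be told apart, and neither stands out in this assay. Compound 3 `Cc1nc2cc(C(F)(F)F)ccc2n1-c1ccc(C(=O)NC2CC2)s1` has trifluoromethyl in place of methyl on an aromatic carbon. Among the compounds with values here, no measured pair shows this change directly. Within the data shown here, the only guide is compound 2, whose 10 mL/min/kg lies within the scatter of compound 1. The expected 1.3-fold higher number from compound 1 to compound 3 (0.10 log units; within the scatter) therefore stays within the scatter, with no clear direction. For compound 3 the estimated clearance is 10 mL/min/kg, with an expected range of 6 mL/min/kg to 20 mL/min/kg.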

Compound 3, clearance: 4 mL/min/kg
Compound 3: the middle estimate sits 2.5-fold (0.40 log units) above what was measured; the whole stated range lies above it.
By their numbers in this assay, from the lowest: compounds 3, 1 and 2 (each within the scatter of the next, the first and the last beyond it).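

Trifluoromethyl in place of methyl on an aromatic carbon gives a 2.0-fold lower number from compound 1 to compound 3 (0.30 log units; within the scatter) in this assay and so stays within the scatter of repeated measurements. Within the data shown here, this is the first direct reading of this change, and it shows that this position takes the larger group without a clear shift in clearance. Nothing at hand accounts for the size or direction of this step. From the compounds shown here alone, whether an amine, a carboxylic acid or a longer chain on this aromatic carbon would also leave clearance unchanged remains open.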